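The compounds below may be only part of what the source reports. "The series", "measured", "known", "first", "only" and "open" are said of these compounds alone.

Notes on the series in a functional assay on SK-BR-3 cells (Homo sapiens) for antiproliferative activity, read by MTT assay, with a stated time of 72 h; on this read-out higher numbers stand for weaker inhibition and lower numbers for stronger inhibition. Compound 1 `C/C=C1/[C@H](O[C@@H]2O[C@H](CO)[C@@H](O)[C@H](O)[C@H]2O)OC=C(C(=O)OC)[C@H]1CC(=O)OCC` gives only a limit, > 15000 nM. Compound 3 `C/C=C1/[C@H](O[C@@H]2O[C@H](CO)[C@@H](O)[C@H](O)[C@H]2O)OC=C(C(=O)OC)[C@H]1CC(=O)O` likewise gives only a limit, > 15000 nM. Between them, a step that the two limits leave unreadable from compound 1 to compound 3 cannot be read in size. Compound 2 `C/C=C1/[C@H](O[C@@H]2O[C@H](COC(C)=O)[C@@H](OC(C)=O)[C@H](OC(C)=O)[C@H]2OC(C)=O)OC=C(C(=O)OC)[C@H]1CC(=O)OCCC1CCCCC1` also stands at a limit, > 15000 nM. All values shown rest at the limit of > 15000 nM in this assay, at which 3 of the 3 values shown sit. Compound 4 `C/C=C1/[C@H](O[C@@H]2O[C@H](COC(C)=O)[C@@H](OC(C)=O)[C@H](OC(C)=O)[C@H]2OC(C)=O)OC=C(C(=O)OC)[C@H]1CC(=O)OCCC(C)C` differs from compound 2 by isopropyl in place of cyclohexyl on a saturated chain carbon, two bonds along the chain from an oxygen next to a carbonyl group. For the measured compounds named here, no measured step bears on this change, and the one measured step is itself unreadable, so no step beyond the scatter in either direction can be expected in this assay. Compound 4 is expected at 20000 nM, within 8000 nM to 60000 nM, most probably again only a limit. The expected step is a step that the limit leaves unreadable from compound 2 to compound 4.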

Compound 4, half-maximal inhibitory concentration: > 15000 nM
Compound 4: only a limit was reported (the forecaster's own chance of this, stated with the estimate: 85%); the middle value lies beyond the limit too.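

For the compounds shown here, compound 2 and compound 4 both rest only at a limit, so no step between them can be read: the limit of > 15000 nM in this assay, at which 4 of the 4 values shown sit.
As far as these compounds go, whether isopropyl and cyclohexyl differ at all in this assay stays open, as does whether any compound on the shared core gives a value short of that limit.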